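A Chlorophenyl Amide on a Core That Shows No Activity

The compounds below may be only part of what the source reports. "The series", "measured", "known", "first", "only" and "open" are said of these compounds alone.

Measured compounds:
compound 1 `O=C(Nc1ccc(Cl)c(-c2nnc3c(Cl)cccn23)c1)c1ccc(C(F)(F)F)cc1Cl`: > 100000 nM
compound 2 `O=C(Nc1ccc(Cl)c(-c2nnc3c(Cl)cccn23)c1)c1ccon1`: > 100000 nM

Both compounds share one core and differ only in the aromatic ring attached to the amide carbonyl. In a functional assay on T47D cells (Homo sapiens) for antiproliferative activity, read by MTT assay, with a stated time of 72 h (a higher number here means a weaker inhibitor, a lower number a stronger inhibitor), compound 1 gives > 100000 nM, which is a limit of the assay and not a measured number. Compound 2 gives > 100000 nM in this assay, again a limit rather than a number. For the measured compounds named here, compound 2 therefore stands at the limit of > 100000 nM in this assay, at which 2 of the 2 values shown sit, and nothing measured so far separates it from compound 1.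

Compound 3 `O=C(Nc1ccc(Cl)c(-c2nnc3c(Cl)cccn23)c1)c1ccccc1Cl` keeps the same core and carries the change (2-chlorophenyl in place of 1,2-oxazol-3-yl on a carbonyl carbon). Going by the values given here, no step between two measured compounds with a known number is available, so the size of any effect of this change cannot be read from the data. With compound 1 also at its limit in this assay, there is no sign that any amide aryl ring on this core reaches measurable potency. The expected step is a number no higher from compound 2 to compound 3 (the limit leaves the size open), none beyond the scatter. Compound 3 is accordingly estimated at 100000 nM, with a range from 20000 nM to 300000 nM, most likely reported only as a limit.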

Compound 3, half-maximal inhibitory concentration: 83800 nM
The estimate for compound 3 lay 1.2-fold (0.08 log units) above the measured number; measured number inside the range.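

For the compounds shown here, compound 3 is the first compound on the shared core to give a real number rather than a limit in this assay, so this place on the carbonyl carbon now has a fixed point against which later changes can be measured. Putting 2-chlorophenyl in place of 1,2-oxazol-3-yl gives an at least 1.1-fold lower number from compound 2 to compound 3 (0.07 log units; that floor lies within the scatter), and hydrogen in place of trifluoromethyl on an aromatic carbon gives an at least 1.1-fold lower number from compound 1 to compound 3 (0.07 log units; that floor lies within the scatter). Both figures are only floors and neither shows a real gain in potency, and the true size of both steps stays unknown, as compound 1 and compound 2 each remain a limit of the assay and not a number: the limit of > 100000 nM in this assay, at which 2 of the 3 values shown sit.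

Still open, as far as these compounds go, is whether an amine or a carboxylic acid on the 2-chlorophenyl ring, or a longer chain in place of that ring on the carbonyl carbon, would move the number well beyond the scatter. Equally open, from the compounds shown here alone, is how a plain phenyl ring at this place would compare with 2-chlorophenyl, which would show whether the chlorine itself matters.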